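Stability notes on the step from compound 2 to compound 4

The source may hold more compounds than are shown below. What is called first, only, known or untested is meant among the compounds shown, and "the series" means these compounds.

In an ADME assay on S9 fraction from liver (Homo sapiens) for metabolic stability, read by LC-MS, using NADPH, with stated times of 5 min and 60 min, tested at 5 uM (on this read-out lower numbers stand for a less stable compound and higher numbers for a more stable compound), compound 2 `COc1cc(C2CN(C(=O)c3cc(OC[C@@H](O)CO)ccn3)C2)ccc1OCc1ccc(C2CC2)cc1` gives 63% and compound 3 `CCc1ccc(COc2ccc(C3CN(C(=O)c4cc(COC[C@@H](O)CO)ccn4)C3)cc2OC)cc1` gives 54% as a pair within the scatter of each other. Compound 1 `COc1ccc(COc2ccc(C3CN(C(=O)c4cc(OCCO)ccn4)C3)cc2OC)cc1` gives 38% and lies lower than compound 2 beyond the scatter. Compound 4 `COc1cc(C2CN(C(=O)c3cc(COC[C@H](O)CO)ccn3)C2)ccc1OCc1ccc(C2CC2)cc1` has (2,3-dihydroxypropoxy)methyl in place of 2,3-dihydroxypropoxy on an aromatic carbon relative to compound 2. Going by the values given here, no measured pair isolates this change. Compound 3 also carries a (2,3-dihydroxypropoxy)methyl group and gives 54% here, so no shift beyond the scatter is expected in this assay for this change. The expected step of a number 5 percentage points lower from compound 2 to compound 4 (within the scatter) is small and stays within the scatter. The estimate for compound 4 is 58% with an expected range of 42% to 74% in this read-out.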

Compound 4, percent of the compound remaining: 62%
Beside the measured number, compound 4's estimate is 4 percentage points below it, and the stated range covers the measured number.
By their numbers in this assay, from the lowest: compound 1; then compounds 3, 4 and 2 (each within the scatter of the next).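

In this assay, going by these compounds alone, the change from 2,3-dihydroxypropoxy to (2,3-dihydroxypropoxy)methyl on this aromatic carbon, opposite the ring nitrogen, shows a number 1 percentage points lower from compound 2 to compound 4 (within the scatter) as the first reading that isolates it. With the rest of the structure held fixed, this read-out does not tell the two groups apart. Nothing measured here offers an explanation for this result.

As far as these compounds go, whether an amine, a carboxylic acid or a longer chain carrying the diol at this place would also leave the read-out unmoved remains open. From the compounds shown here alone, the same change on a different benzyl ether also remains untested as an isolated pair.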